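This account rests on a few compounds, and the source may have more. Where it says the series, first, only, none or still open, it means among the compounds named here.

Measured in a functional assay on cells (Homo sapiens) for inhibition, read by MTT assay, with a stated time of 72 h; on this read-out lower numbers stand for stronger inhibition and higher numbers for weaker inhibition:
compound 1 `CCOC(=O)Cn1ncc2c(Nc3ccc(NC(=O)CCl)cc3)ncnc21` gives 7.27 ug/mL
compound 2 `CCOC(=O)Cn1ncc2c(Nc3ccc(NS(=O)(=O)c4ccccc4)cc3)ncnc21` gives > 100 ug/mL

Compound 2 stands at the top of these numbers. For compound 2 the value > 100 ug/mL is a limit of this assay, not a number (the limit of > 100 ug/mL in this assay, at which 1 of the 2 values shown sits). Compound 3 `O=C(O)Cn1ncc2c(Nc3ccc(NS(=O)(=O)c4ccccc4)cc3)ncnc21` differs from compound 2 in one place: hydrogen in place of ethyl on an oxygen next to a carbonyl group. Going by the values given here, the only measured step, an at least 13-fold higher number from compound 1 to compound 2 (1.13 log units; beyond the scatter), changes a different group and so does not bear on this ester-to-acid change; no comparable step is available. Compound 3 is therefore expected to remain at or near the limit, an expected step that the limit leaves unreadable from compound 2 to compound 3. The estimate for compound 3 is 150 ug/mL, between 50 ug/mL and 500 ug/mL.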

Compound 3, half-maximal inhibitory concentration: > 100 ug/mL
Compound 3 gave a limit, no number; the forecaster's own chance of this, stated with the estimate: 80%; the middle value is on the limit's open side.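

No step can be read from compound 2 to compound 3, as each gives only a limit in this assay, not a number: the limit of > 100 ug/mL in this assay, at which 2 of the 3 values shown sit.

The compounds shown leave open whether the change from ethoxycarbonyl to carboxy alters inhibition at all.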